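Iodo in place of cyclohexyl: a first expectation

A few compounds are considered here, and "the series" means these few. Any claim that something is new, unique, unknown or untested is made for them only; others in the source may bear on it.

In a functional assay on MCF7 cells (Homo sapiens) for inhibition, read by sulforhodamine B assay, with a stated time of 48 h (on this read-out lower numbers stand for stronger inhibition of growth and higher numbers for weaker inhibition of growth), compound 1 (`c1cc(C2CCCCC2)ccc1NC1=NCCO1`) gives 17500 nM, compound 2 (`c1ccc(Oc2cccc(NC3=NCCO3)c2)cc1`) gives 12200 nM and compound 3 (`c1ccc(COc2cccc(NC3=NCCO3)c2)cc1`) gives 2600 nM. Compound 1 therefore stands at the high end of this small set, within the scatter of compound 2 and beyond the scatter from compound 3, which shows the lowest number of the three.

The next compound to be read is compound 4 (`Ic1ccc(NC2=NCCO2)cc1`). It has iodo in place of cyclohexyl on an aromatic carbon, and the count of that change is iodo in place of cyclohexyl on an aromatic carbon.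

For the measured compounds named here, no pair of measured compounds differs in one place only, so the set gives no direct measure of this replacement. The substituent on compound 3, at 2600 nM, offers no close guide to iodo, and the single clear departure in the set cannot be carried over to compound 4. With nothing pointing firmly in either direction, no change beyond the scatter is expected in this assay, and a slight lowering is the most that is anticipated. The expected size of the change is a 1.5-fold lower number from compound 1 to compound 4 (0.16 log units; within the scatter).

For compound 4 the estimated value is 12000 nM, with an expected range of 4000 nM to 35000 nM.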

Compound 4, concentration for 50% growth inhibition: 2900 nM
The estimate for compound 4 lay 4.1-fold (0.62 log units) above the measured number, outside the stated range (below it).
By their numbers in this assay, from the lowest: compounds 3 and 4 (each within the scatter of the next); then compounds 2 and 1 (each within the scatter of the next).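

Working notes: in this assay, a 6.0-fold lower number from compound 1 to compound 4 (0.78 log units; beyond the scatter) is the first step in the series that changes one place only, and it lies beyond the scatter, so the substituent on this aromatic carbon of the six-membered aromatic ring of carbon only clearly affects the read-out. The cyclohexyl group, with its 6 heavy atoms and six-membered non-aromatic ring of carbon only, is not needed at this position for the lower number, since a single iodine atom in its place gives the stronger inhibition of growth. Nothing at hand explains the step, and it cannot be assigned to any one difference between the two groups.

On these data alone, a single pair cannot show a trend across substituents at this position, so it remains open whether the lower number is specific to iodo or would also appear with hydrogen, bromo, methyl, an amine or a carboxylic acid. As far as these compounds go, it also remains open whether a longer chain or a phenyl ring on the same carbon would move the number towards that of compound 1 or that of compound 4.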